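Replacing the 3-oxopiperazin-1-yl group of compound 3

A few compounds are considered here, and "the series" means these few. Any claim that something is new, unique, unknown or untested is made for them only; others in the source may bear on it.

Of the compounds shown here, three sharing one core have been measured in an ADME assay on microsomes from liver (Mus musculus) for metabolic stability, read by LC-MS, using NADPH, with stated times of 10 min and 30 min, tested at 1 uM; on this read-out higher numbers stand for fast clearance and lower numbers for slow clearance. Compound 1 `COC(=O)C1=C(C)NC(c2nccs2)=NC1(C)c1ccc(Cl)cc1` gives 85 mL/min/kg, compound 2 `COC(=O)C1=C(C)NC(c2nccs2)=NC1(C)c1ccc(C#N)cc1` gives 75 mL/min/kg and compound 3 `COC(=O)C1=C(CN2CCNC(=O)C2)NC(c2nccs2)=NC1(C)c1ccc(F)cc1` gives 81 mL/min/kg. These three values lie within the scatter of one another, so compound 3 stands level with the other two on these numbers.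

Compound 4 `COC(=O)C1=C(CN(C)C2(C(=O)O)CC2)NC(c2nccs2)=NC1(C)c1ccc(F)cc1` has not yet been measured. Its structure departs from that of compound 3 in a single place: a group of 8 heavy atoms (5 carbon, 1 nitrogen, 2 oxygen; one three-membered non-aromatic ring of carbon only) in place of a group of 7 heavy atoms (4 carbon, 2 nitrogen, 1 oxygen; one six-membered non-aromatic ring with 2 hetero atoms), on a saturated chain carbon bound to a double-bonded ring carbon. The 3-oxopiperazin-1-yl group leaves, and the entering group, which has no common name, carries a three-membered non-aromatic ring of carbon only.

Going by the values given here, only one measured step bears on this, and only indirectly: a 1.1-fold lower number from compound 1 to compound 2 (0.05 log units; within the scatter), with cyano in place of chloro on an aromatic carbon. Among the compounds with values here, that step is within the scatter, but it lies at another place in the structure, and no measured pair covers the present replacement. The data therefore give no ground for a step beyond the scatter. The expected step in this assay is small and stays within the scatter: a 1.4-fold lower number from compound 3 to compound 4 (0.13 log units; within the scatter). Compound 4 is expected at 60 mL/min/kg, with an estimated range from 20 mL/min/kg to 90 mL/min/kg, kept wide since so little bears on this change.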

Compound 4, clearance: 42 mL/min/kg
Estimate against measurement, compound 4: 1.4-fold (0.15 log units) above, and the stated range covers the measured number.
By their numbers in this assay, from the lowest: compounds 4, 2, 3 and 1 (each within the scatter of the next, the first and the last beyond it).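

Going by these compounds alone, until now the only step that could be read lay on an aromatic carbon. Within the data shown here, compound 4 gives the first reading of a change on a saturated chain carbon bound to a double-bonded ring carbon, and in this assay the exchange gives a 1.9-fold lower number from compound 3 to compound 4 (0.29 log units; within the scatter), so this place accepts a group with a three-membered non-aromatic ring of carbon only in place of the 3-oxopiperazin-1-yl group without a step beyond the scatter. Nothing among the data shown offers an explanation for this result.

The compounds shown leave open which part of the entering group matters for the reading, since the three-membered ring, the carboxylic acid and the methyl on nitrogen all enter together in this one exchange. As far as these compounds go, how a morpholin-4-yl group, a dimethylamino group or a longer chain ending in a carboxylic acid would read at this place in this assay also stays open, as does the same exchange on the chloro or cyano compounds.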